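Removing the 3,4-dichlorophenyl from compound 1

The source may hold more compounds than are shown below. What is called first, only, known or untested is meant among the compounds shown, and "the series" means these compounds.

Three measured compounds frame the question. In a functional assay on the whole organism (B cells) with Mus musculus as the target (on this read-out lower numbers stand for smaller maximal responses and higher numbers for larger maximal responses), compound 1 `Nc1nc(O)c2c(n1)n(C1OC(CO)[C@@H](O)[C@H]1O)c(=O)n2Cc1ccc(Cl)c(Cl)c1` gives 55%, the lowest of the three numbers. Compound 2 `C=CCn1c(=O)n(CCC(CCOCc2ccccc2)CCOCc2ccccc2)c2nc(N)nc(O)c21` gives 68%, above compound 1 by a margin beyond the scatter, and compound 3 `C=CCn1c(=O)n(CCCC)c2nc(N)nc(O)c21` gives 77%, further above compound 1 again. Among the compounds with values here, no two of these differ in one place only, so no single step is available. Compound 4 `Cn1c(=O)n(C2OC(CO)[C@@H](O)[C@H]2O)c2nc(N)nc(O)c21` is not yet measured; it differs from compound 1 by hydrogen in place of 3,4-dichlorophenyl on a saturated chain carbon bound to an aromatic nitrogen. Compound 2 and compound 3 both sit higher than compound 1, and compound 4 is expected to move toward them. The step of a number 13 percentage points higher from compound 1 to compound 4 (beyond the scatter) is thus expected to exceed the scatter. Compound 4 is estimated at 68%, expected between 50% and 88%.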

Compound 4, largest response reached (reported as maximal response), in percent of the reference or control that the assay uses: 99%
For compound 4 the middle estimate is 31 percentage points below the measured one; measured number outside the range, above it.
By their numbers in this assay, from the lowest: compound 1; then compounds 2 and 3 (each within the scatter of the next); then compound 4.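

Working in this assay, the first single-place comparison in the series shows that this position strongly affects the read-out: 3,4-dichlorobenzyl to methyl, with the rest of the core of compound 1 unchanged, gives a number 44 percentage points higher from compound 1 to compound 4 (beyond the scatter) on the saturated chain carbon bound to an aromatic nitrogen. The smaller maximal response therefore goes with the 3,4-dichlorophenyl in this pair. Nothing available explains the size of this step.

Open, from the compounds shown here alone, is whether the step follows the two chlorines or the phenyl ring itself, which an unsubstituted benzyl would separate. Going by these compounds, how an ethyl or a longer chain, or an amine, would read here also remains open.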